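This account rests on a few compounds, and the source may have more. Where it says the series, first, only, none or still open, it means among the compounds named here.

Measured in a functional assay on DU-145 cells (Homo sapiens) for inhibition, read by trypan blue exclusion, with a stated time of 96 h; on this read-out lower numbers stand for stronger inhibition of growth and higher numbers for weaker inhibition of growth:
- compound 1 `O=C(O)c1ccc(C(=O)/C(=C\c2ccc(O)c([N+](=O)[O-])c2)SCc2ccc(Br)cc2)cc1`: 50000 nM
- compound 2 `O=C(/C(=C\c1ccc(O)c([N+](=O)[O-])c1)SCc1ccc(Br)cc1)c1ccc(Br)cc1`: 10000 nM

Compound 2 has the lower of the two numbers. Compound 3 `O=C(/C(=C\c1ccc(O)c(C(=O)O)c1)SCc1ccc(Br)cc1)c1ccc(Br)cc1` has carboxy in place of nitro on an aromatic carbon, ortho to a hydroxy group (carboxy in place of nitro on an aromatic carbon). Among the compounds with values here, only one measured step bears on this, and only indirectly: a 5.0-fold lower number from compound 1 to compound 2 (0.70 log units; beyond the scatter), a modest change in which a carboxy left at a different place. A modest step to a higher number is therefore expected in this assay, though this change itself has not been measured. The expected step is a 2.0-fold higher number from compound 2 to compound 3 (0.30 log units; within the scatter). Compound 3 is estimated at 20000 nM, with an expected range of 6000 nM to 60000 nM.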

Compound 3, concentration for 50% growth inhibition: 10000 nM
Compound 3: middle estimate off by 2.0-fold (0.30 log units), on the high side, within the range that was stated.
By their numbers in this assay, from the lowest: compounds 2 and 3 (each within the scatter of the next); then compound 1.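

In this assay, carboxy in place of nitro, ortho to a hydroxy group, gives no change at the digits printed from compound 2 to compound 3 (within the scatter) and so leaves the read-out unmoved at this position. The earlier step, a 5.0-fold lower number from compound 1 to compound 2 (0.70 log units; beyond the scatter), concerned a carboxy at a different place, and its size does not carry over to this one. No evidence at hand explains why these two groups read alike here.

Going by these compounds, whether an amine or a methoxy group at this position would also leave the number in place remains open, as does the role of the neighbouring hydroxy group.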